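Methoxy-to-hydrogen step on the shared core

The compounds below may be only part of what the source reports. "The series", "measured", "known", "first", "only" and "open" are said of these compounds alone.

Compound 1 `Fc1ccc(/C=C/c2cc3ccccc3nc2Cl)cc1` and compound 2 `COc1ccc2nc(Cl)c(/C=C/c3ccc(F)cc3)cc2c1` differ by hydrogen in place of methoxy on an aromatic carbon. In an ADME assay on 184B5 cells (Homo sapiens) for antiproliferative activity, read by sulforhodamine B assay, with a stated time of 72 h (a higher number here means a weaker inhibitor, a lower number a stronger inhibitor), compound 2 gives 9740 nM, and compound 1 gives 38500 nM; the step is a 4.0-fold higher number from compound 2 to compound 1 (0.60 log units; beyond the scatter). Compound 3 `COc1ccc2nc(Cl)c(/C=C\c3cc(C(F)(F)F)cc(C(F)(F)F)c3)cc2c1` keeps the methoxy of compound 2 but on a different remainder; the difference between the two cores is not broken down here. In this assay compound 3 gives 7970 nM, close to the number for compound 2, so no order between the two can be read. Compound 4 `FC(F)(F)c1cc(/C=C\c2cc3ccccc3nc2Cl)cc(C(F)(F)F)c1` stands to compound 3 as compound 1 stands to compound 2: hydrogen in place of methoxy on an aromatic carbon, and the place is described in the same words, so this is the same kind of change. In this assay the step is expected to be about a 3.8-fold higher number from compound 3 to compound 4 (0.58 log units; beyond the scatter), set beside the measured one, because a 4.0-fold higher number from compound 2 to compound 1 (0.60 log units; beyond the scatter) was seen for the same change on the other remainder. Within the data shown here, compound 4 is thus expected near 30000 nM, in a range from 12000 nM to 75000 nM; the range is wide since only one earlier instance of the change is known.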

Compound 4, half-maximal inhibitory concentration: 13700 nM
For compound 4 the middle estimate is 2.2-fold (0.34 log units) above the measured one, and the stated range covers the measured number.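

In this assay, hydrogen in place of methoxy on the second core gives a 1.7-fold higher number from compound 3 to compound 4 (0.24 log units; within the scatter), so on this core alone the change cannot be told from repeat-measurement noise. Set beside the earlier instance, the two steps do not differ measurably, and the change carries from one core to the other as far as these two pairs can show: the same change on two cores in this assay, a 4.0-fold higher number (0.60 log units; beyond the scatter) from compound 2 to compound 1 and a 1.7-fold higher number (0.24 log units; within the scatter) from compound 3 to compound 4, 2.3-fold (0.36 log units) apart, within the scatter of two such steps This agreement does not establish a fixed size for the step, since there are only two pairs, one of them within the scatter, and it does not show that methoxy contributes on the core of compound 3 or say why the values fall as they do.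

The compounds shown leave open how an amine, a hydroxyl group or a longer alkoxy chain on this aromatic carbon would compare with methoxy and hydrogen in this assay. They also leave open whether the step would hold on any remainder other than the two seen here.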